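Small steps among three halogen compounds, one methoxy to come

This account rests on a few compounds, and the source may have more. Where it says the series, first, only, none or still open, it means among the compounds named here.

Values from a functional assay on SW-620 cells (Homo sapiens) for cytotoxicity, read by MTT assay, with a stated time of 72 h (on this read-out lower numbers stand for stronger inhibition and higher numbers for weaker inhibition), so far:
- compound 1 `COc1cccc(/C=C2\CCC/C(=C\c3ccccc3Cl)C2=O)c1OC` gives 10300 nM
- compound 2 `COc1cccc(/C=C2\CCC/C(=C\c3ccccc3Br)C2=O)c1OC` gives 12100 nM
- compound 3 `COc1cccc(/C=C2\CCC/C(=C\c3cccc(Br)c3)C2=O)c1OC` gives 8800 nM

Compound 2 gives 12100 nM and does not separate from the other two compounds, as a 1.2-fold higher number from compound 1 to compound 2 (0.07 log units; within the scatter) and a 1.4-fold lower number from compound 2 to compound 3 (0.14 log units; within the scatter) both show. Compound 4 `COc1ccccc1/C=C1\CCC/C(=C\c2cccc(OC)c2OC)C1=O` has not yet been measured. It differs from compound 2 in one place (methoxy in place of bromo on an aromatic carbon) so that 2-bromophenyl becomes 2-methoxyphenyl.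

Among the compounds with values here, no measured compound carries methoxy in that place, so the data hold no direct precedent for this change. The nearest evidence comes from halogen changes alone. Bromo in place of chloro on an aromatic carbon gives a 1.2-fold higher number from compound 1 to compound 2 (0.07 log units; within the scatter) and the other halogen comparison gives a 1.2-fold lower number from compound 1 to compound 3 (0.07 log units; within the scatter) as its result. These steps are all small, but they cannot show what methoxy will do.

No step beyond the scatter is therefore expected in either direction, and the estimated step is a 1.2-fold lower number from compound 2 to compound 4 (0.08 log units; within the scatter) for this change. Compound 4 is expected at 10000 nM with an estimated range of 4000 nM to 25000 nM in this assay once it is tested.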

Compound 4, half-maximal inhibitory concentration: > 20000 nM
Compound 4: no number, only a limit; the forecaster's own chance of this, stated with the estimate: 3%; middle value at least 2.0-fold (0.30 log units) away from the limit.
By their numbers in this assay, from the lowest: compounds 3, 1 and 2 (each within the scatter of the next). At a limit, above all of these: compound 4.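

In this assay compound 4 has a limit rather than a number, so its true value is not known: the limit of > 20000 nM in this assay, at which 1 of the 4 values shown sits. Replacing bromo with methoxy at this place on the aromatic ring gives an at least 1.6-fold higher number from compound 2 to compound 4 (0.21 log units; that floor lies within the scatter), and replacing chloro with methoxy gives an at least 1.9-fold higher number from compound 1 to compound 4 (0.28 log units; that floor lies within the scatter), so neither floor alone separates compound 4 from the halogen compounds with an ortho substituent. Within the data shown here, the comparison with the remaining halogen compound does separate them, giving an at least 2.2-fold higher number from compound 3 to compound 4 (0.35 log units; beyond the scatter), which is the first step in this small set to pass beyond the scatter and shows that a change of 2-substituted phenyl group can matter here, where the steps among the halogen compounds alone could not show it.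

Going by these compounds, how far compound 4 really lies from compound 1 and compound 2 stays unknown while its reading is only a limit, so the full size of the methoxy step cannot be given. Also open, on these data alone, is whether a different group in the same place, such as an amine, a carboxylic acid or a longer chain ending in an ether oxygen, would stay with the halogen compounds or move as methoxy does.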